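The compounds below may be only part of what the source reports. "The series", "measured", "known", "first", "only" and "open" are said of these compounds alone.

Measured compounds:
- compound 1, `COc1cccc(/C=C/C(=O)c2sc(Nc3ccc(Cl)c(Cl)c3)nc2C)c1`: 8350 nM
- compound 2, `COc1cc(/C=C/C(=O)c2sc(Nc3ccc(C)cc3)nc2C)cc(OC)c1OC`: > 25000 nM

Both were tested in a functional assay on BGC-823 cells (Homo sapiens) for cytotoxicity, read by MTT assay; on this read-out higher numbers stand for weaker inhibition and lower numbers for stronger inhibition. Compound 1 gives 8350 nM. For compound 2 the result is a limit of the assay, (the limit of > 25000 nM in this assay, at which 1 of the 2 values shown sits), not a number. Compound 3, `COc1cc(/C=C/C(=O)c2sc(Nc3ccccc3)nc2C)cc(OC)c1OC`, has not been measured yet. It differs from compound 2 in one place: hydrogen in place of methyl on an aromatic carbon, the hydrogen taking the place of the methyl on an aromatic carbon of a six-membered aromatic ring of carbon only, para to a large group; one bond further out this reads as 4-methylphenyl to phenyl. Among the compounds with values here, with compound 2 standing at the limit (the limit of > 25000 nM in this assay, at which 1 of the 2 values shown sits), no measured step shows what removing this methyl does. The change is expected to be small, a step that the limit leaves unreadable from compound 2 to compound 3, in neither direction beyond the usual scatter. Compound 3 is therefore estimated at 30000 nM, with a range from 10000 nM to 90000 nM, and is most likely again reported only as a limit.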

Compound 3, half-maximal inhibitory concentration: > 25000 nM
Compound 3: no number, only a limit (the forecaster's own chance of this, stated with the estimate: 60%); the middle value lies beyond the limit too.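

No step can be read from compound 2 to compound 3, because each is reported only as a limit and not as a number: the limit of > 25000 nM in this assay, at which 2 of the 3 values shown sit. As far as these compounds go, what removing the methyl from 4-methylphenyl does in this assay stays open, as does how far either compound lies past that limit.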